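A larger chain on the amino-acid carbon of compound 2

A few compounds are considered here, and "the series" means these few. Any claim that something is new, unique, unknown or untested is made for them only; others in the source may bear on it.

The series rests on one shared core carrying an amino-acid unit whose side chain is varied. Compound 1 `NC(=O)CC[C@H](NC(=O)CN(c1ncnc2c1ncn2C1CCCCO1)C1CC1)C(=O)OCc1ccccc1` bears a 2-carbamoylethyl group there and gives in a functional assay on the whole organism (Tail, strain ICR) with Mus musculus as the target, in the tail flick test, with a stated time of 90 min, at a dose of 25 umol/kg by the oral route (on this read-out higher numbers stand for a stronger effect at the one dose given and lower numbers for a weaker effect), a read-out of 37.8%. Compound 2 `C[C@@H](O)[C@H](NC(=O)CN(c1ncnc2c1ncn2C1CCCCO1)C1CC1)C(=O)OCc1ccccc1` carries a 1-hydroxyethyl group instead and gives 23.4%. Among the measured compounds shown here, compound 2 thus stands lowest of the two measured compounds, and the single step from it, a number 14.4 percentage points lower from compound 1 to compound 2 (beyond the scatter), is the only one that bears on the question.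

Compound 3 `N=C(N)NCCC[C@H](NC(=O)CN(c1ncnc2c1ncn2C1CCCCO1)C1CC1)C(=O)OCc1ccccc1` is the next compound. Its change from compound 2 is a group of 7 heavy atoms (4 carbon, 3 nitrogen; no ring) in place of a group of 3 heavy atoms (2 carbon, 1 oxygen; no ring), on a saturated chain carbon bound to an amide-type nitrogen and a carbonyl carbon. For the measured compounds named here, the one measured step shows that replacing the 1-hydroxyethyl group by a longer chain of 3 heavy atoms more raised the read-out beyond the scatter, and the group entering compound 3 is again longer than 1-hydroxyethyl, so an upward step of similar size is expected, a number 11.6 percentage points higher from compound 2 to compound 3 (beyond the scatter). Going by the values given here, only one step supports this, so the range stays wide. Compound 3 is therefore estimated at 35%, between 18% and 52%.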

Compound 3, a percentage reported as activity, at one dose (the size of the read-out at that dose, not a potency): 61.6%
For compound 3 the middle estimate is 26.6 percentage points below the measured one; the measured number lies above the stated range.
By their numbers in this assay, from the lowest: compound 2; then compound 1; then compound 3.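

Compound 3 shows that this position, a saturated chain carbon bound to an amide-type nitrogen and a carbonyl carbon, can carry much more than the two earlier side chains suggested: in this assay, the group of 7 heavy atoms (4 carbon, 3 nitrogen) gives a number 38.2 percentage points higher from compound 2 to compound 3 (beyond the scatter) in place of 1-hydroxyethyl, a large step. Compound 3 also stands clear of the better earlier compound, with a number 23.8 percentage points higher from compound 1 to compound 3 (beyond the scatter), so the two earlier read-outs did not mark the top of what this position can give. Among these three compounds alone, with none going against it, the read-out climbs from 1-hydroxyethyl through 2-carbamoylethyl to the group in compound 3, yet nothing measured here says which feature of that group accounts for the gain.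

Size and the nitrogen content of the entering group change together in these compounds, so their separate contributions remain unresolved. Going by these compounds, it also remains open how an amine, a carboxylic acid or a plain longer hydrocarbon chain would fare on the same saturated chain carbon, and whether the climb would continue with any of them.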